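The source may hold more compounds than are shown below. What is called first, only, known or untested is meant among the compounds shown, and "the series" means these compounds.

Measured compounds:
Compound 1, `CSc1ccc(C)cc1NCC1=NCCN1`, 0.11 nM.
Compound 2, `Cc1ccc(S(C)(=O)=O)c(NCC2=NCCN2)c1`, 1.95 nM.
Compound 3, `CS(=O)(=O)c1ccc(Cl)cc1NCC1=NCCN1`, 2.82 nM.

The three were examined in a functional assay for agonist activity at Alpha-1A adrenergic receptor (Homo sapiens); on this read-out higher numbers stand for an effect only at larger amounts of compound and lower numbers for an effect already at smaller amounts. Compound 2 and compound 3 share a core and differ in one place, (chloro in place of methyl on an aromatic carbon); the step of a 1.4-fold higher number from compound 2 to compound 3 (0.16 log units; within the scatter) lies within the scatter, so the two values cannot be told apart. Compound 1 and compound 2 differ in another place, (methylsulfanyl in place of methylsulfonyl on an aromatic carbon), and this change made the large step of an 18-fold lower number from compound 2 to compound 1 (1.25 log units; beyond the scatter).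

Compound 4, `CSc1ccc(Cl)cc1NCC1=NCCN1`, has not been measured in this assay. It differs from compound 3 in the same way that compound 1 differs from compound 2: methylsulfanyl in place of methylsulfonyl on an aromatic carbon. The surroundings are not identical, since in compound 1 the place is para to a methyl group whereas in compound 4 it is para to a chloro group, so this is the same kind of change rather than the same change. Because the step of an 18-fold lower number from compound 2 to compound 1 (1.25 log units; beyond the scatter) was large and because the step of a 1.4-fold higher number from compound 2 to compound 3 (0.16 log units; within the scatter) showed that methyl and chloro at that place gave values within the scatter of each other, the expected step for compound 4 in this assay is an 18-fold lower number from compound 3 to compound 4 (1.25 log units; beyond the scatter). Compound 4 is estimated to give 0.16 nM, expected to fall between 0.05 nM and 0.6 nM.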

Compound 4, half-maximal effective concentration: 0.437 nM
Compound 4: middle estimate off by 2.7-fold (0.44 log units), on the low side; the measured number falls inside the stated range.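

In this assay, methylsulfanyl in place of methylsulfonyl again gave a lower number, with a 6.5-fold lower number from compound 3 to compound 4 (0.81 log units; beyond the scatter) on the chloro-bearing core, so the direction of this change held on both cores, but its size did not carry over unchanged: the same change on two cores in this assay, an 18-fold lower number (1.25 log units; beyond the scatter) from compound 2 to compound 1 and a 6.5-fold lower number (0.81 log units; beyond the scatter) from compound 3 to compound 4, 2.7-fold (0.44 log units) apart, beyond the scatter of two such steps.

Chloro in place of methyl gave a 4.0-fold higher number from compound 1 to compound 4 (0.60 log units; beyond the scatter) where methylsulfanyl is present, a step beyond the scatter, whereas the same exchange where methylsulfonyl is present stayed within it: the same change on two cores in this assay, a 1.4-fold higher number (0.16 log units; within the scatter) from compound 2 to compound 3 and a 4.0-fold higher number (0.60 log units; beyond the scatter) from compound 1 to compound 4, 2.7-fold (0.44 log units) apart, beyond the scatter of two such steps.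

Across these four compounds, then, the effect of each change depended on the group present at the other place, so a step read on one core gave the direction of the sulfur change on the other but not its size; this rests on only two pairs for each change, and it does not show why the steps differ or how either change would behave on any further core.

The compounds shown leave open whether the sulfur change would keep its direction with fluoro, methoxy or plain hydrogen in place of chloro or methyl. They also leave open where methylsulfinyl, or a longer chain on the sulfur such as ethylsulfanyl, would fall among these values.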